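Changing the carbonyl amine of compound 2

The source may hold more compounds than are shown below. What is called first, only, known or untested is meant among the compounds shown, and "the series" means these compounds.

In a functional assay on A549 cells (Homo sapiens) for inhibition, read by sulforhodamine B assay, with a stated time of 72 h (a higher number here means a weaker inhibitor, a lower number a stronger inhibitor), compound 1 (`Nc1sc(-c2ccc(Cl)cc2)c(-c2ccc(Cl)cc2)c1C(=O)NC1CCCCC1`) gives 2410 nM and compound 2 (`CC1CCN(C(=O)c2c(N)sc(-c3ccc(Cl)cc3)c2-c2ccc(Cl)cc2)CC1`) gives 1750 nM within the scatter of each other. Compound 3 (`CCOC(=O)Nc1sc(-c2ccc(Cl)cc2)c(-c2ccc(Cl)cc2)c1C(=O)NC1CC1`) gives 39800 nM as a far higher number, so compound 2 sits at the low end of the three, level with compound 1. Compound 4 (`Nc1sc(-c2ccc(Cl)cc2)c(-c2ccc(Cl)cc2)c1C(=O)N1CCOCC1`) follows from compound 2 by morpholin-4-yl in place of 4-methylpiperidin-1-yl on a carbonyl carbon with morpholin-4-yl in place of 4-methylpiperidin-1-yl on a carbonyl carbon. Within the data shown here, the only measured step at this place is a 1.4-fold lower number from compound 1 to compound 2 (0.14 log units; within the scatter) and no single-place step connects compound 3. No step beyond the scatter is therefore expected in this assay and the estimate is a 1.4-fold higher number from compound 2 to compound 4 (0.15 log units; within the scatter) as the expected change. For compound 4 the expected value is 2500 nM with an estimated range from 1000 nM to 7000 nM in this measurement.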

Compound 4, half-maximal inhibitory concentration: 1870 nM
Estimate against measurement, compound 4: 1.3-fold (0.13 log units) above, within the range that was stated.
By their numbers in this assay, from the lowest: compounds 2, 4 and 1 (each within the scatter of the next); then compound 3.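

In this assay, the morpholin-4-yl amide sits level with both earlier amides: a 1.1-fold higher number from compound 2 to compound 4 (0.03 log units; within the scatter), and a 1.3-fold lower number from compound 1 to compound 4 (0.11 log units; within the scatter). Thus a ring oxygen and a hydrogen-bond acceptor can enter on this carbonyl carbon, in place of 4-methylpiperidin-1-yl, with no change beyond the scatter. No supporting measurement bears on why these three amides read alike.

On these data alone, whether a piperazin-1-yl ring with its second amine nitrogen, or a carboxylic acid on the ring, would separate from these values remains open. So does whether any group at this position can move the number beyond the scatter.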